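This account rests on a few compounds, and the source may have more. Where it says the series, first, only, none or still open, it means among the compounds named here.

In a functional assay on the whole organism (strain Wistar) for inhibition, with Rattus norvegicus as the target, read by paw edema, with a stated time of 3 h, at a dose of 120 mg/kg by the oral route (a higher number here means more inhibition at the dose given (going by the name of the read-out), a lower number less inhibition), three compounds have been tested so far. Compound 1 `NC(=O)c1c(CSCC(=O)Oc2ccccc2C(=O)O)no[n+]1[O-]` gives 39.4%, compound 2 `N#Cc1nonc1CSCC(=O)Oc1ccccc1C(=O)O` gives 38.9%, and compound 3 `O=C(CCOc1nonc1-c1ccccc1)Oc1ccccc1C(=O)O` gives 38.6%. Compound 2 holds the second highest of the three numbers, yet its nearest neighbour, compound 3, sits only a little lower and compound 1 only a little higher, and both of these gaps fall within the scatter of repeated measurements, so the three results cannot be told apart. No pair of these compounds differs in only one place, so no single step between measured compounds is available to guide an expectation.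

Compound 4 `NC(=O)c1nonc1CSCC(=O)Oc1ccccc1C(=O)O` has not yet been measured in this assay. It differs from compound 2 in one place: carbamoyl in place of cyano on an aromatic carbon. Going by the values given here, with no measured step to lean on, and with all three known numbers so close together, a change of this kind is expected to move the number by nothing beyond the scatter. The expected step is a number 0.1 percentage points higher from compound 2 to compound 4 (within the scatter). Compound 4 is therefore expected to give about 39%, with a range from 30% to 48%.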

Compound 4, a percentage reported as inhibition, in the whole organism at one dose (the size of the read-out at that dose, not a potency) in the Rattus norvegicus assay: 39.6%
The estimate for compound 4 lay 0.6 percentage points below the measured number; the range from low to high includes it.
By their numbers in the Rattus norvegicus assay, from the lowest: compounds 3, 2, 1 and 4 (each within the scatter of the next).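

Going by these compounds alone, in the Rattus norvegicus assay the change from cyano to carbamoyl on this aromatic carbon gives the first step between compounds that differ in one place, a number 0.7 percentage points higher from compound 2 to compound 4 (within the scatter) and so shows that the added hydrogen-bond donor and the extra heavy atom leave the inhibition at this dose indistinguishable. In a physicochemical assay for pharmacokinetics, read by HPLC, in phosphate buffer, at pH 7.4, tested at 100 uM (on this read-out higher numbers stand for a longer-lived compound and lower numbers for a shorter-lived compound), compound 2 gives 0.633 h and compound 4 gives 0.833 h, which is a 1.3-fold higher number from compound 2 to compound 4 (0.12 log units; within the scatter) and so the same change separates the two compounds no more clearly on this read-out. Nothing at hand offers an explanation for either result.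

As far as these compounds go, whether an amine or a carboxylic acid at this position would move either number beyond the scatter remains open. A longer chain there is equally untested among the compounds shown.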